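From a Free Amine to an Isothiocyanate Tail

This account rests on a few compounds, and the source may have more. Where it says the series, first, only, none or still open, it means among the compounds named here.

Among the compounds with values here, compound 2 `Cc1ccc(-c2nnc(-c3ccc(CN4CCN(CCN)CC4)c(C(F)(F)F)c3)o2)cc1Nc1nccc(-c2cccnc2)n1` gives 20 nM in a functional assay on HL-60 cells (Homo sapiens) for inhibition, read by MTT assay, with a stated time of 72 h (on this read-out lower numbers stand for stronger inhibition and higher numbers for weaker inhibition), the only plain number in the set. Compound 1 `Cc1ccc(-c2nnc(-c3ccc(C)c(C(F)(F)F)c3)o2)cc1Nc1nccc(-c2cccnc2)n1` reaches only a limit of the assay, > 30000 nM. Compound 3 `Cc1ccc(-c2nnc(-c3ccc(CN4CCN(CCN=C=S)CC4)c(C(F)(F)F)c3)o2)cc1Nc1nccc(-c2cccnc2)n1` differs from compound 2 by a group of 3 heavy atoms (1 carbon, 1 nitrogen, 1 sulfur; no ring) in place of one nitrogen atom, on a saturated chain carbon, two bonds along the chain from an amine nitrogen in a ring. Within the data shown here, the one measured step, an at least 1500-fold lower number from compound 1 to compound 2 (3.17 log units; beyond the scatter), concerns a different change and does not address this one; it shows only how much the tail region can matter, as the limit of > 30000 nM in this assay, at which 1 of the 2 values shown sits, marks. Compound 3 is therefore expected at 40 nM, with a range from 8 nM to 200 nM. This means an expected step of a 2.0-fold higher number from compound 2 to compound 3 (0.30 log units; within the scatter), small and uncertain.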

Compound 3, half-maximal inhibitory concentration: 70 nM
For compound 3 the middle estimate is 1.8-fold (0.24 log units) below the measured one, within the range that was stated.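

Swapping the amino group at the end of the chain for the isothiocyanate in this assay weakens inhibition only modestly, with a 3.5-fold higher number from compound 2 to compound 3 (0.54 log units; beyond the scatter). A free amino group at this position is therefore not required for strong inhibition, and the piperazine tail still leaves a large difference from the untailed compound, with an at least 420-fold lower number from compound 1 to compound 3 (2.63 log units; beyond the scatter). That size has no exact value, since compound 1 gives only a limit of the assay, > 30000 nM.

Going by these compounds, whether a carboxylic acid or a longer chain would be tolerated at this position stays open. Nothing shown here explains why the step has this size.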